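This account rests on a few compounds, and the source may have more. Where it says the series, first, only, none or still open, it means among the compounds named here.

In a functional assay on SK-BR-3 cells (Homo sapiens) for antiproliferative activity (a higher number here means a weaker inhibitor, a lower number a stronger inhibitor), compound 1 `COc1ccc(C(=O)Nc2cc3ccc(OC4CCN(C)CC4)c(C)c3oc2=O)cc1CC=C(C)C` gives 1410 nM. Among the compounds with values here, its only measured neighbour, compound 2 `C#CCOc1ccc(C(=O)Nc2cc3ccc(OC4CCN(C)CC4)c(C)c3oc2=O)cc1CC=C(C)C`, gives 1400 nM, so compound 1 stands level with it, within the usual scatter of such measurements.

The next compound, compound 3 `COc1ccc(C(=O)Nc2cc3ccc(OC4CCN(C)CC4)c(C)c3oc2=O)cc1-c1cccc(OC(C)=O)c1`, keeps the shared core but changes a different group. On an aromatic carbon, ortho to a methoxy group, 3-acetoxyphenyl takes the place of 3-methylbut-2-en-1-yl: 3-acetoxyphenyl in place of 3-methylbut-2-en-1-yl on an aromatic carbon. This swaps an open chain for an aromatic ring that carries an acetoxy group.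

Within the data shown here, the only measured step is a 1.0-fold lower number from compound 1 to compound 2 (0.00 log units; within the scatter), which lies within the scatter. It adds ethynyl to the methoxy group, so it leaves the 3-methylbut-2-en-1-yl group untouched and offers only indirect guidance. Among the measured compounds shown here, no measured compound shows what happens when that group is replaced. With nothing to set a direction, no shift beyond the scatter is expected, though the uncertainty is wide.

The estimated change is a 1.8-fold lower number from compound 1 to compound 3 (0.25 log units; within the scatter). For compound 3, the expected value is 800 nM, with an estimated range from 200 nM to 3000 nM.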

Compound 3, half-maximal inhibitory concentration: 290 nM
Compound 3: the middle estimate sits 2.8-fold (0.44 log units) above what was measured; measured number inside the range.
By their numbers in this assay, from the lowest: compound 3; then compounds 2 and 1 (each within the scatter of the next).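

In this assay, the aromatic carbon ortho to a methoxy group proves responsive: 3-acetoxyphenyl in place of 3-methylbut-2-en-1-yl gives a 4.9-fold lower number from compound 1 to compound 3 (0.69 log units; beyond the scatter) and so moves the number beyond the scatter, while the earlier change on the methoxy group gave only a 1.0-fold lower number from compound 1 to compound 2 (0.00 log units; within the scatter) and stayed within it. The open chain is therefore not required at this position, and a larger group with an aromatic ring and two hydrogen-bond acceptors is accepted there with a gain in potency. This single step changes size, ring content and acceptor count together, so it cannot separate their contributions, and no supporting data point to a cause for the gain.

The compounds shown leave open whether the gain comes from the aromatic ring alone or needs the acetoxy group, a question that an unsubstituted phenyl ring or a phenyl ring carrying a hydroxyl group or an amine at the same place would address. Also open, as far as these compounds go, is whether the ethynyl change, silent on the 3-methylbut-2-en-1-yl compounds, would stay silent alongside 3-acetoxyphenyl.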